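Ester to Amide Swap Across Two Cores and Solubility

The compounds below may be only part of what the source reports. "The series", "measured", "known", "first", "only" and "open" are said of these compounds alone.

The study compares four compounds in a physicochemical assay for solubility; a lower number here means a less soluble compound, a higher number a more soluble compound. Compound 1 `COC(=O)c1ccc(NC(=O)c2ccc3ccccc3n2)cc1` and compound 2 `NC(=O)c1ccc(NC(=O)c2ccc3ccccc3n2)cc1` share one core; compound 3 `COC(=O)c1cccc(NC(=O)c2cc3cc([N+](=O)[O-])ccc3s2)c1` and compound 4 `NC(=O)c1cccc(NC(=O)c2cc3cc([N+](=O)[O-])ccc3s2)c1` share another. How the two cores differ is not broken down here.

Compound 1 gives 25 ug/mL in this assay, and compound 2 gives 5 ug/mL. The change from compound 1 to compound 2 is amino in place of methoxy on a carbonyl carbon and it produced a 5.0-fold lower number from compound 1 to compound 2 (0.70 log units; beyond the scatter).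

Compound 3 gives 25 ug/mL in this assay, which at the digits shown is level with compound 1 and within the scatter of it. The change from compound 3 to compound 4 is amino in place of methoxy on a carbonyl carbon and it is the same change, made at the same kind of place, as that from compound 1 to compound 2.

Among the measured compounds shown here, on the strength of the single earlier step of a 5.0-fold lower number from compound 1 to compound 2 (0.70 log units; beyond the scatter), compound 4 is expected to move by about a 5.0-fold lower number from compound 3 to compound 4 (0.70 log units; beyond the scatter) in this assay. Compound 4 is therefore estimated at 5 ug/mL, with a likely range from 2 ug/mL to 12 ug/mL.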

Compound 4, solubility: 25 ug/mL
Compound 4: middle estimate off by 5.0-fold (0.70 log units), on the low side; measured number outside the range, above it.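

In this assay, amino in place of methoxy on a carbonyl carbon gave no change at the digits printed from compound 3 to compound 4 (within the scatter) in one core, while the same change in the other core gave a 5.0-fold lower number from compound 1 to compound 2 (0.70 log units; beyond the scatter), so the drop seen in the first pair did not carry over to the second. This shows that, in this series, the step measured on one core was no reliable guide to the step on the other, but with a single pair per core it does not show which feature of the cores separates the two results, or whether either pair is typical of its core. Nothing available accounts for the difference between the two pairs.

The compounds shown leave open how a carboxylic acid or a dimethylamino group on the same carbonyl carbon would read in this assay on either core. They also leave open whether a further core would follow the first pair, the second pair or neither.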